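Allyloxycarbonyl in place of the thiazolyl carbonyl on compound 2

The source may report more compounds than this note shows. Statements on the series, on what has been measured and on what is new or still open speak of the compounds shown alone.

Compound 1 `O=C(Nc1ccc2nc(NC(=O)C3CCCCC3)sc2c1)c1ccccc1Cl` gives 0.025 ug/mL in a functional assay on WI-38 VA13 cells (Homo sapiens) for cytotoxicity; a higher number here means that more compound is needed for the effect, a lower number that less compound is needed. Going by the values given here, compound 2 `Cc1nc(C)c(C(=O)Nc2ccc3nc(NC(=O)C4CCCCC4)sc3c2)s1` gives 0.39 ug/mL in this assay; the only step between measured compounds, a 16-fold higher number from compound 1 to compound 2 (1.19 log units; beyond the scatter), is large, so compound 2 stands with the highest of the two numbers seen so far, its nearest neighbour being compound 1 at a far lower number. Compound 3 `C=CCOC(=O)Nc1ccc2nc(NC(=O)C3CCCCC3)sc2c1` is reached from compound 2 by allyloxy in place of 2,4-dimethyl-1,3-thiazol-5-yl on a carbonyl carbon. Among the compounds with values here, the one measured step that bears on this position is a 16-fold higher number from compound 1 to compound 2 (1.19 log units; beyond the scatter), which shows that the group on this carbonyl carbon moves the number strongly; no measured compound carries an allyloxy there, so the direction of the coming step is open. A further rise in the number, a fall back towards compound 1, or no change beyond the scatter are all plausible, and the expectation is correspondingly wide. For compound 3 the estimate in this assay is 1 ug/mL with a range of 0.15 ug/mL to 6 ug/mL. The expected step is a 2.6-fold higher number from compound 2 to compound 3 (0.41 log units; beyond the scatter).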

Compound 3, half-maximal effective concentration: 0.58 ug/mL
For compound 3 the middle estimate is 1.7-fold (0.24 log units) above the measured one, and the stated range covers the measured number.
By their numbers in this assay, from the lowest: compound 1; then compounds 2 and 3 (each within the scatter of the next).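

In this assay the step shows a 1.5-fold higher number from compound 2 to compound 3 (0.17 log units; within the scatter) and so does not separate allyloxy, which has no ring, from 2,4-dimethyl-1,3-thiazol-5-yl, which has a five-membered aromatic ring; on this carbonyl carbon, a group without a ring therefore sits at the same level as this heteroaromatic group. The second step, a 23-fold higher number from compound 1 to compound 3 (1.37 log units; beyond the scatter), confirms with a group of a different kind that 2-chlorophenyl stands apart, leaving compound 1 with the lowest number of the three compounds and compounds 2 and 3 together at a clearly separate level. The data at hand offer no explanation of why 2-chlorophenyl stands apart from the other two groups.

The compounds shown leave open whether the low number of compound 1 depends on the chlorine or on the phenyl ring itself, a question that an unsubstituted phenyl group on this carbonyl carbon would address. Also open, going by these compounds, is whether the level shared by compounds 2 and 3 extends to other groups at this place, such as a longer alkoxy chain, a simple methyl or an amine.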